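Removing a Chloro Group: Expected Clearance of Compound 3

The source may hold more compounds than are shown below. What is called first, only, known or untested is meant among the compounds shown, and "the series" means these compounds.

compound 1, `COc1cnc(-c2ccccn2)nc1N1CCCC1`: 987 mL/min/kg
compound 2, `COc1cnc(-c2ccccn2)nc1NCc1ccccc1Cl`: 827 mL/min/kg

In an in vitro ADME assay on microsomes from liver (Rattus norvegicus) for metabolic stability, read by LC-MS, tested at 0.05 uM (on this read-out lower numbers stand for slow clearance and higher numbers for fast clearance), compound 1 gives 987 mL/min/kg and compound 2 gives 827 mL/min/kg. The two numbers sit within the scatter of each other, so compound 2 stands level with compound 1, both at fast clearance. Among the measured compounds shown here, compound 3, `COc1cnc(-c2ccccn2)nc1NCc1ccccc1`, differs from compound 2 by hydrogen in place of chloro on an aromatic carbon; no measured pair shows this change. Because compound 2 already gives 827 mL/min/kg, a shift beyond the scatter is not expected in either direction. Compound 3 is therefore expected to give 900 mL/min/kg (range 450 mL/min/kg to 1800 mL/min/kg), an expected step of a 1.1-fold higher number from compound 2 to compound 3 (0.04 log units; within the scatter).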

Compound 3, clearance: 387 mL/min/kg
Beside the measured number, compound 3's estimate is 2.3-fold (0.37 log units) above it, outside the stated range (below it).
By their numbers in this assay, from the lowest: compound 3; then compounds 2 and 1 (each within the scatter of the next).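

In this assay, replacing the chloro of the 2-chlorophenyl group with hydrogen gives a 2.1-fold lower number from compound 2 to compound 3 (0.33 log units; beyond the scatter), a modest step but one beyond the scatter. Among the compounds shown here, this shows that the substituent at this place on the ring can shift clearance, which the earlier compounds could not show, and that here the plain phenyl group gives the slower clearance. No measured evidence explains the step. Going by these compounds, whether a fluoro, methyl or methoxy group at the same place would match hydrogen or chloro stays open. So does whether a chloro elsewhere on the ring would give a similar number.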